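Cytotoxicity of a Fluorinated Chromone Series: Three Limits and a Guess

The source may report more compounds than this note shows. Statements on the series, on what has been measured and on what is new or still open speak of the compounds shown alone.

In a functional assay on HeLa cells (Homo sapiens) for cytotoxicity, read by neutral red uptake, with a stated time of 3 days (on this read-out higher numbers stand for weaker inhibition and lower numbers for stronger inhibition), compound 1 `CCCCc1c(F)c(N)c2c(=O)cc(-c3ccc(N)c(F)c3)oc2c1F` gives only a limit, > 100000 nM.
In this assay compound 2 `C[S+]([O-])c1c(F)c(N)c2c(=O)cc(-c3ccc(N)c(F)c3)oc2c1F` gives only a limit, > 100000 nM.
In this assay compound 3 `CCCCCCOCc1c(F)c(N)c2c(=O)cc(-c3ccc(N)c(F)c3)oc2c1F` likewise gives only a limit, > 100000 nM.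

Compound 3 therefore stands at the ceiling of the assay, with no number of its own. Compound 4 `CN(C)CCCOCc1c(F)c(N)c2c(=O)cc(-c3ccc(N)c(F)c3)oc2c1F` differs from it by dimethylamino in place of propyl on a saturated chain carbon, three bonds along the chain from an oxygen on a saturated carbon. Among the measured compounds shown here, none of the measured steps can guide this change: the steps a step that the two limits leave unreadable from compound 1 to compound 2, a step that the two limits leave unreadable from compound 1 to compound 3 and a step that the two limits leave unreadable from compound 2 to compound 3 all run between limits, because the limit of > 100000 nM in this assay, at which 3 of the 3 values shown sit, holds every value shown. With nothing readable to build on, compound 4 is expected to stay near that same ceiling, so the step that the limit leaves unreadable from compound 3 to compound 4 is estimated at nil beyond the scatter. Compound 4 is thus estimated at 150000 nM, within a range of 30000 nM to 600000 nM.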

Compound 4, half-maximal inhibitory concentration: 12000 nM
Beside the measured number, compound 4's estimate is 13-fold (1.10 log units) above it; the measured number lies below the stated range.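

Placing dimethylamino in place of propyl on a saturated chain carbon, three bonds along the chain from an oxygen on a saturated carbon, gives an at least 8.3-fold lower number from compound 3 to compound 4 (0.92 log units; beyond the scatter) in this assay and shows that a change at this chain end can move the read-out. The other routes to compound 4 agree, with an at least 8.3-fold lower number from compound 2 to compound 4 (0.92 log units; beyond the scatter) and an at least 8.3-fold lower number from compound 1 to compound 4 (0.92 log units; beyond the scatter) as the result. The steps among the earlier compounds cannot be read, because those compounds give no number of their own: the limit of > 100000 nM in this assay, at which 3 of the 4 values shown sit.

The compounds shown leave open whether a primary amine or a carboxylic acid at this chain end would move the read-out as dimethylamino does.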